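Nitrile to carboxylic acid in the phenoxyalkyl chain

The compounds below may be only part of what the source reports. "The series", "measured", "known", "first", "only" and "open" are said of these compounds alone.

Three members of the series have been run in an assay on isolated protein for inhibition of leukotriene B4 receptor 1 (Homo sapiens), tested at 10 uM; a higher number here means more inhibition at the concentration tested (going by the name of the read-out), a lower number less inhibition. Compound 1 `CCCc1cc(C(C)=O)c(O)cc1OCCCCC#N` gives 84% in this assay, compound 2 `CCc1cc(C(C)=O)c(O)cc1OCCCC(C)(C)C#N` gives 85%, and compound 3 `CCc1cc(C(C)=O)c(O)cc1OCCCC(C)(C)C(=O)O` gives 89%. The change from compound 2 to compound 3 is carboxy in place of cyano on a saturated chain carbon bound to three saturated chain carbons; it produced a number 4 percentage points higher from compound 2 to compound 3 (within the scatter). How the core of compound 1 differs from that of compound 2 is not broken down here. Compound 4 `CCCc1cc(C(C)=O)c(O)cc1OCCCCC(=O)O` carries the same kind of change against compound 1, namely (carboxy in place of cyano on a saturated chain carbon, four bonds along the chain from an oxygen on an aromatic ring); what differs around the place is that in compound 3 the carboxy sits on a saturated chain carbon bound to three saturated chain carbons, whereas in compound 4 it sits on a saturated chain carbon, four bonds along the chain from an oxygen on an aromatic ring. Going by the values given here, compound 4 is expected to show a step of a number 4 percentage points higher from compound 1 to compound 4 (within the scatter), because a number 4 percentage points higher from compound 2 to compound 3 (within the scatter) is the only measured reading of this change. For compound 4 the estimate in this assay is 88%, with a range from 80% to 95%.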

Compound 4, a percentage reported as inhibition, at one concentration (the size of the read-out at that concentration, not a potency): 11%
The estimate for compound 4 lay 77 percentage points above the measured number; measured number below the stated range.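

Carboxy in place of cyano gives a number 73 percentage points lower from compound 1 to compound 4 (beyond the scatter) in this assay, with the change on a saturated chain carbon, four bonds along the chain from an oxygen on an aromatic ring. Set against the earlier step, the change does not carry from one core to the other as a fixed amount: the same change on two cores in this assay, a number 4 percentage points higher (within the scatter) from compound 2 to compound 3 and a number 73 percentage points lower (beyond the scatter) from compound 1 to compound 4, 77 percentage points apart, beyond the scatter of two such steps

The two pairs differ from each other in more than one place, so these compounds do not show which difference decides the outcome, and two pairs give no rule for other cores.

Open, from the compounds shown here alone, is whether the core of compound 1 and the chain of compound 3 each contribute to the gap. Also open, going by these compounds, is how a longer chain ending in carboxy, or an amide or tetrazole in its place, would read.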